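This account rests on a few compounds, and the source may have more. Where it says the series, first, only, none or still open, it means among the compounds named here.

In an ADME assay on cells (Hepatocyte, Canis lupus familiaris) for metabolic stability, read by LC-MS, with a stated time of 40 min (a higher number here means that more of the compound is left, a lower number that less of the compound is left), compound 1 `CN1CCC[C@H](NC(=O)[C@H]2CN(S(=O)(=O)c3ccccc3)C[C@@H]2NC(=O)c2cc(-c3ccccc3Cl)on2)C1` gives 78% and compound 2 `O=CN1CCC[C@H](NC(=O)[C@H]2CN(S(=O)(=O)c3ccccc3)C[C@@H]2NC(=O)c2cc(-c3ccccc3Cl)on2)C1` gives 16%, which leaves compound 2 with the lower of the two numbers. Compound 3 `CC(=O)N1CCC[C@H](NC(=O)[C@H]2CN(S(=O)(=O)c3ccccc3)C[C@@H]2NC(=O)c2cc(-c3ccccc3Cl)on2)C1` differs from compound 2 by methyl in place of hydrogen on a carbonyl carbon, with methyl in place of hydrogen on a carbonyl carbon, so that formyl becomes acetyl. Within the data shown here, only one measured step touches this group, a number 62 percentage points lower from compound 1 to compound 2 (beyond the scatter), and it is large. Among the measured compounds shown here, no measured pair compares formyl with acetyl directly, so that step is a loose guide. An upward move of smaller size is expected, given as a number 24 percentage points higher from compound 2 to compound 3 (beyond the scatter). Compound 3 is estimated at 40%, within a range of 18% to 70%.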

Compound 3, percent of the compound remaining: 43%
Compound 3: middle estimate off by 3 percentage points, on the low side; measured number inside the range.
By their numbers in this assay, from the lowest: compound 2; then compound 3; then compound 1.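

Methyl in place of hydrogen on a carbonyl carbon gives a number 27 percentage points higher from compound 2 to compound 3 (beyond the scatter) in this assay and so shows that what the carbonyl carries matters at this nitrogen. Acetyl in place of methyl on the amine nitrogen in a ring still gives a number 35 percentage points lower from compound 1 to compound 3 (beyond the scatter) and so does not reach the number of compound 1. Nothing measured explains either step.

On these data alone, whether a longer acyl chain, a carbamate or a urea on this nitrogen would sit nearer compound 1 stays open. So does how an ethyl group in place of the methyl of compound 1 would read.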